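Sulfonamide series: carboxy in place of 4-chlorophenyl

This account rests on a few compounds, and the source may have more. Where it says the series, first, only, none or still open, it means among the compounds named here.

Compound 1 `COc1ccc(Cl)cc1S(=O)(=O)Nc1cncc(-c2ccc(Cl)cc2)c1` carries a 4-chlorophenyl group on the pyridine-type ring of the shared core. Within the data shown here, in an assay on isolated protein for inhibition of alkaline phosphatase, tissue-nonspecific isozyme (Homo sapiens) (on this read-out lower numbers stand for stronger inhibition and higher numbers for weaker inhibition), compound 1 gives "not determined" (no result reported), so it stands nowhere on the numbers so far; the only measured member is compound 2 `COc1ccc(OC(F)(F)F)cc1S(=O)(=O)Nc1cncc(C(N)=O)c1`, which in this assay gives 1560 nM. Among the measured compounds shown here, no step between measured compounds is available, and compound 2 differs from compound 1 in more than one place, so nothing can be read from that pair beyond the single value it shows.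

Compound 3 `COc1ccc(Cl)cc1S(=O)(=O)Nc1cncc(C(=O)O)c1` is the next member to be measured. Relative to compound 1 the difference is carboxy in place of 4-chlorophenyl on an aromatic carbon, on an aromatic carbon of a six-membered aromatic ring with one nitrogen, two atoms from the ring nitrogen and meta to a large group. For the measured compounds named here, with no anchor value for compound 1, the size and direction of this step in this assay cannot be projected; the expectation rests only on the one reading at hand and is wide. Taking the reading of compound 2 in this assay at 1560 nM as the nearest reference, compound 3 is expected near 3000 nM, within a range of 500 nM to 20000 nM.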

Compound 3, half-maximal inhibitory concentration: > 20000 nM
Compound 3: no number, only a limit (the forecaster's own chance of this, stated with the estimate: 25%); middle value at least 6.6-fold (0.82 log units) from the limit.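

No step can be read between compound 1 and compound 3: compound 1 has no single number. In this assay compound 3 gives > 20000 nM, which is a limit and not a number. The compounds shown leave open how large the change is for carboxy in place of 4-chlorophenyl, and in which direction it runs.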